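Benzylamine in place of arylamine on the shared core

The compounds below may be only part of what the source reports. "The series", "measured", "known", "first", "only" and "open" are said of these compounds alone.

Measured compounds in a functional assay on NCI-H1299 cells (Homo sapiens) for antiproliferative activity, read by MTT assay, with a stated time of 72 h; a higher number here means a weaker inhibitor, a lower number a stronger inhibitor:
compound 1 `O=C(C1=C(Nc2ccc(F)cc2)C(=O)N(CCCn2ccnc2)C1c1ccc(Br)cc1)c1ccccc1` gives 25400 nM
compound 2 `O=C(C1=C(Nc2ccc(Cl)cc2)C(=O)N(CCCn2ccnc2)C1c1ccc(Br)cc1)c1ccccc1` gives 25000 nM

Compound 2 and compound 1 give numbers that lie within the scatter of each other, as the step of a 1.0-fold lower number from compound 1 to compound 2 (0.01 log units; within the scatter) shows; the two therefore stand together, and neither can be called stronger or weaker. Compound 3 `O=C(C1=C(NCc2ccccc2)C(=O)N(CCCn2ccnc2)C1c1ccc(Br)cc1)c1ccccc1` differs from compound 2 by benzyl in place of 4-chlorophenyl on an amine nitrogen. For the measured compounds named here, the only measured step, chloro in place of fluoro on an aromatic carbon, bears on this change only loosely, since it alters a substituent while the change to compound 3 replaces the whole 4-chlorophenyl group by benzyl. Going by the values given here, no measured pair covers this kind of exchange, so the expectation rests on the two values alone and carries a wide range. For compound 3 the expected step of no change at the digits printed from compound 2 to compound 3 (within the scatter) is none beyond the scatter. Compound 3 is estimated at 25000 nM, within 7000 nM to 90000 nM.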

Compound 3, half-maximal inhibitory concentration: 25300 nM
For compound 3 the middle estimate is 1.0-fold (0.01 log units) below the measured one, and the stated range covers the measured number.
By their numbers in this assay, from the lowest: compounds 2, 3 and 1 (each within the scatter of the next).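

In this assay, the exchange on the amine nitrogen gives a 1.0-fold higher number from compound 2 to compound 3 (0.01 log units; within the scatter) and a 1.0-fold lower number from compound 1 to compound 3 (0.00 log units; within the scatter). The earlier pair had varied only the halogen on the aromatic ring, whereas compound 3 shows that the whole aryl group at this nitrogen can be replaced by benzyl, which carries no halogen, with all three numbers remaining within the scatter of one another. No supporting evidence is available to explain this result. From the compounds shown here alone, whether a different group on this nitrogen, such as a short alkyl chain, a cyclohexylmethyl group or a benzyl bearing a carboxylic acid, would separate from these three numbers remains open. Going by these compounds, all three compounds also keep the rest of the shared core unchanged, so it is equally open whether this reading would hold if another part were altered.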